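This account rests on a few compounds, and the source may have more. Where it says the series, first, only, none or still open, it means among the compounds named here.

Measured compounds:
- compound 1, `N=C(N)NCCC[C@H](NC(=O)CN(c1nc(Cl)nc2[nH]cnc12)C1CC1)C(=O)OCc1ccccc1`: 23.2%
- compound 2, `NC(=O)CC[C@H](NC(=O)CN(c1ncnc2c1ncn2C1CCCCO1)C1CC1)C(=O)OCc1ccccc1`: 47%
- compound 3, `CC[C@H](C)[C@H](NC(=O)CN(c1ncnc2c1ncn2C1CCCCO1)C1CC1)C(=O)OCc1ccccc1`: 25.6%

In a functional assay on the whole organism (Tail, strain ICR) with Mus musculus as the target, in the tail flick test, with a stated time of 30 min, at a dose of 25 umol/kg by the oral route (on this read-out lower numbers stand for a weaker effect and higher numbers for a stronger effect at the one dose given), compound 1 stands lowest of the three numbers; compound 3 lies within the scatter of it, while compound 2 lies beyond the scatter above it. Compound 4, `NC(=O)CC[C@H](NC(=O)CN(c1nc(Cl)nc2[nH]cnc12)C1CC1)C(=O)OCc1ccccc1`, keeps the core of compound 1 and changes the side chain: a group of 3 heavy atoms (1 carbon, 1 nitrogen, 1 oxygen; no ring) in place of a group of 5 heavy atoms (2 carbon, 3 nitrogen; no ring), on a saturated chain carbon, three bonds along the chain from an amide-type nitrogen and a carbonyl carbon. Carbamoyl enters. Among the compounds with values here, no measured step covers this exact exchange. Within the data shown here, the one step that bears on the side chain is a number 21.4 percentage points lower from compound 2 to compound 3 (beyond the scatter), which shows that the chain carrying carbamoyl sits well above the sec-butyl chain on the other core. Compound 4 is therefore expected to gain a moderate amount, the expected step being a number 16.8 percentage points higher from compound 1 to compound 4 (beyond the scatter). Compound 4 is estimated at 40% with a range from 22% to 60%.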

Compound 4, a percentage reported as activity, at one dose (the size of the read-out at that dose, not a potency): 30.8%
For compound 4 the middle estimate is 9.2 percentage points above the measured one; measured number inside the range.
By their numbers in this assay, from the lowest: compounds 1, 3 and 4 (each within the scatter of the next); then compound 2.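

In this assay, carbamoyl in place of the group of 5 heavy atoms at this position on the core of compound 1 gives a number 7.6 percentage points higher from compound 1 to compound 4 (within the scatter), so this exchange does not separate the two compounds. Within the data shown here, the side-chain step on the other core, a number 21.4 percentage points lower from compound 2 to compound 3 (beyond the scatter), is a different exchange, involves sec-butyl and has no counterpart on this core. No measurement available here explains the result.

Open, going by these compounds, is whether a carboxylic acid or a primary amine at this position would stand apart from carbamoyl on the core of compound 1. Also open, on these data alone, is whether sec-butyl would do so on that core.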